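A few compounds are considered here, and "the series" means these few. Any claim that something is new, unique, unknown or untested is made for them only; others in the source may bear on it.

Compound 1 `COc1cc([C@](O)(CCN(C)C)[C@@H](c2cc3cc(Br)ccc3nc2OC)c2cccc(OC)c2F)cc(OC(F)F)n1` and compound 2 `COc1cc([C@](O)(CCN(C)C)[C@@H](c2cc3cc(Br)ccc3nc2OC)c2ccnc(OC)c2OC)cc(OC(F)F)n1` share one core and differ in a single group: 2,3-dimethoxypyridin-4-yl in place of 2-fluoro-3-methoxyphenyl on a saturated chain carbon bound to an aromatic carbon and a saturated chain carbon. In an ADME assay on microsomes from liver (Homo sapiens) for metabolic stability (on this read-out higher numbers stand for fast clearance and lower numbers for slow clearance), compound 1 gives 0.1 uL/min, and compound 2 gives 2.1 uL/min, a change of a 21-fold higher number from compound 1 to compound 2 (1.32 log units; beyond the scatter). Compound 3 `COc1cccc([C@H](c2cc3cc(Br)ccc3nc2OC)[C@@](O)(CCN(C)C)c2cc(SC)nc(SC)c2)c1F` stands on a different core; how it differs from compound 1 is a group of 10 heavy atoms (7 carbon, 1 nitrogen, 2 sulfur; one six-membered aromatic ring with 1 hetero atom) in place of a group of 12 heavy atoms (7 carbon, 1 nitrogen, 2 oxygen, 2 fluorine; one six-membered aromatic ring with 1 hetero atom), on a saturated chain carbon bound to an oxygen on a saturated carbon and two saturated chain carbons. In this assay compound 3 gives 3.4 uL/min. Compound 4 `COc1nc2ccc(Br)cc2cc1[C@@H](c1ccnc(OC)c1OC)[C@@](O)(CCN(C)C)c1cc(SC)nc(SC)c1` carries the core of compound 3 together with the same change that turns compound 1 into compound 2: 2,3-dimethoxypyridin-4-yl in place of 2-fluoro-3-methoxyphenyl on a saturated chain carbon bound to an aromatic carbon and a saturated chain carbon, at the same place. Since only one pair has shown this change, and on another core, compound 4 is expected to move by an 8.8-fold higher number from compound 3 to compound 4 (0.95 log units; beyond the scatter), a smaller step than the earlier one. Compound 4 is therefore estimated at 30 uL/min, with a likely range from 8 uL/min to 110 uL/min.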

Compound 4, intrinsic clearance in a liver preparation (reported as CLH), per the amount of preparation that the assay uses: 8.8 uL/min
For compound 4 the middle estimate is 3.4-fold (0.53 log units) above the measured one; the range from low to high includes it.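

In this assay, 2,3-dimethoxypyridin-4-yl in place of 2-fluoro-3-methoxyphenyl again raises the number on the second core, giving a 2.6-fold higher number from compound 3 to compound 4 (0.41 log units; beyond the scatter), so the direction carries over but the size does not: the same change on two cores in this assay, a 21-fold higher number (1.32 log units; beyond the scatter) from compound 1 to compound 2 and a 2.6-fold higher number (0.41 log units; beyond the scatter) from compound 3 to compound 4, 8.1-fold (0.91 log units) apart, beyond the scatter of two such steps

The change that separates the two cores gives a 4.2-fold higher number from compound 2 to compound 4 (0.62 log units; beyond the scatter), also in the same direction as before but by a different amount: the same change on two cores in this assay, a 34-fold higher number (1.53 log units; beyond the scatter) from compound 1 to compound 3 and a 4.2-fold higher number (0.62 log units; beyond the scatter) from compound 2 to compound 4, 8.1-fold (0.91 log units) apart, beyond the scatter of two such steps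

These two pairs show that the size of each step depends on the other part of the molecule, but they do not show why, and two cores cannot say how the change would behave on a third.

From the compounds shown here alone, it remains open what a simple phenyl or a pyridine with a single methoxy group would do at this place. The same question stands for a ring carrying an amine.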